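Methyl removal on the fused-ring core: projected weaker growth inhibition

The source may report more compounds than this note shows. Statements on the series, on what has been measured and on what is new or still open speak of the compounds shown alone.

Measured compounds:
- compound 1, `Oc1cc(-c2ccc(Cl)cc2)nc2ncccc12`: 38900 nM
- compound 2, `COc1ccc(-c2cc(O)c3c(C)cc(C)nc3n2)cc1`: 33100 nM
- compound 3, `Cc1ccnc2nc(-c3ccc(Cl)cc3)cc(O)c12`: 5130 nM

All three were run in a functional assay on cells (Tumor Cell line, Homo sapiens) for cytotoxicity; a lower number here means a stronger inhibitor of growth, a higher number a weaker inhibitor of growth. Compound 3 gives the lowest number of the three. Compound 1 differs from it by hydrogen in place of methyl on an aromatic carbon, and this step, a 7.6-fold higher number from compound 3 to compound 1 (0.88 log units; beyond the scatter), weakens growth inhibition clearly. Compound 2 and compound 1 lie close together in this assay, so no order is read between them. The difference between the core of compound 2 and the core of compound 3 is not broken down here.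

Compound 4, `COc1ccc(-c2cc(O)c3ccc(C)nc3n2)cc1`, is not yet measured. It differs from compound 2 by hydrogen in place of methyl on an aromatic carbon. This is the same kind of change as from compound 3 to compound 1, but the place is not identical: in compound 2 the position is also meta to a methyl group, which the earlier place lacks. The expectation for compound 4 therefore leans on the earlier step, tempered for the different surroundings: an estimated step of a 3.3-fold higher number from compound 2 to compound 4 (0.52 log units; beyond the scatter) is expected, because a 7.6-fold higher number from compound 3 to compound 1 (0.88 log units; beyond the scatter) went the same way. Compound 4 is estimated at 110000 nM, between 40000 nM and 300000 nM.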

Compound 4, concentration for 50% growth inhibition: 91200 nM
The estimate for compound 4 lay 1.2-fold (0.08 log units) above the measured number, within the range that was stated.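

In this assay, hydrogen in place of methyl on an aromatic carbon again weakens growth inhibition, with a 2.8-fold higher number from compound 2 to compound 4 (0.44 log units; beyond the scatter). The direction of the change carries over between the two cores, but its size does not: the same change on two cores in this assay, a 7.6-fold higher number (0.88 log units; beyond the scatter) from compound 3 to compound 1 and a 2.8-fold higher number (0.44 log units; beyond the scatter) from compound 2 to compound 4, 2.8-fold (0.44 log units) apart, beyond the scatter of two such steps. Among the compounds shown here, with only two pairs, this gives no rule for the size of the step on a further core, and it does not show which of the differences between the two cores goes with the gap.

The compounds shown carry only methyl or hydrogen on this aromatic carbon, leaving open how a fluorine atom, an amine or a longer chain such as propyl would read there in this assay. As far as these compounds go, all of them also keep the hydroxyl group on the core, and whether the same change would weaken growth inhibition to a similar degree with an amine or an ether in its place also remains open.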